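Thiosemicarbazones: chain methylation from compound 2 to compound 3

A few compounds are considered here, and "the series" means these few. Any claim that something is new, unique, unknown or untested is made for them only; others in the source may bear on it.

Working notes on the series. Compound 1 `CC(NNC(N)=S)c1ccccc1` carries an unsubstituted phenyl ring. In a functional assay on B16 cells (Mus musculus) for inhibition, with a stated time of 3 days (on this read-out higher numbers stand for weaker inhibition and lower numbers for stronger inhibition), compound 1 gives > 30000 nM, which is a limit of the assay rather than a number (the limit of > 30000 nM in this assay, at which 1 of the 2 values shown sits). Going by the values given here, compound 2 `Cc1ccc(C(C)NNC(N)=S)cc1` adds a methyl on the ring; in this assay compound 2 gives 8100 nM, the only number so far, and the step of an at least 3.7-fold lower number from compound 1 to compound 2 (0.56 log units; beyond the scatter) is beyond the scatter. Compound 3 `CCC(NNC(N)=S)c1ccc(C)cc1` differs from compound 2 by methyl in place of hydrogen on a saturated chain carbon, two bonds along the chain from an amine nitrogen and an aromatic carbon. Among the compounds with values here, the one measured step concerns a methyl on an aromatic carbon, not on the chain, so it bears on this change only loosely; the chain methyl is a small addition and no step beyond the scatter is expected in this assay in either direction. Compound 3 is therefore estimated at 6000 nM (range 2000 nM to 20000 nM), a step of a 1.4-fold lower number from compound 2 to compound 3 (0.13 log units; within the scatter).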

Compound 3, half-maximal inhibitory concentration: 3900 nM
For compound 3 the middle estimate is 1.5-fold (0.19 log units) above the measured one, and the stated range covers the measured number.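

In this assay, the saturated chain carbon, two bonds along the chain from an amine nitrogen and an aromatic carbon, is now shown to respond to substitution: the change from methyl to ethyl at this place gives a 2.1-fold lower number from compound 2 to compound 3 (0.32 log units; beyond the scatter), a modest step. Going by these compounds alone, until now the only measured change lay on the aromatic ring, so this makes a second place on the shared core where an added methyl goes with stronger inhibition. No measurement shown here explains this step.

From the compounds shown here alone, whether the trend continues with a longer chain such as propyl, or with a branched group such as isopropyl, stays open, as does the effect of a hydroxyl or an amine at this carbon. Also open, going by these compounds, is whether the ethyl group gives a similar step on the unsubstituted phenyl ring of compound 1.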